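Chromone acrylamides on liver cells: a chlorophenyl amide

A few compounds are considered here, and "the series" means these few. Any claim that something is new, unique, unknown or untested is made for them only; others in the source may bear on it.

Compounds measured so far in a functional assay on L02 cells (Homo sapiens) for inhibition, read by MTT assay, with a stated time of 48 h; on this read-out lower numbers stand for stronger inhibition and higher numbers for weaker inhibition:
- compound 1 `COc1ccc2c(=O)c(/C=C/C(=O)Nc3ccc(Cl)cc3)coc2c1`: > 200000 nM, a limit of the assay
- compound 2 `CCOc1ccc(NC(=O)/C=C/c2coc3cc(OC)ccc3c2=O)cc1`: > 200000 nM, a limit of the assay
- compound 3 `COc1ccc2c(=O)c(/C=C/C(=O)NCc3ccccc3F)coc2c1`: > 200000 nM, a limit of the assay

Compound 3 thus stands at a limit of the assay rather than at a number, and so do the two other compounds shown. The steps a step that the two limits leave unreadable from compound 1 to compound 2, a step that the two limits leave unreadable from compound 1 to compound 3 and a step that the two limits leave unreadable from compound 2 to compound 3 cannot be read in size or direction, because of the limit of > 200000 nM in this assay, at which 3 of the 3 values shown sit.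

Compound 4 `COc1ccc2c(=O)c(/C=C/C(=O)Nc3ccccc3Cl)coc2c1` differs from compound 3 in one place: 2-chlorophenyl in place of 2-fluorobenzyl on an amide-type nitrogen. Among the measured compounds shown here, none of the measured steps bears on this change in a readable way, since every value shown is a limit. For the measured compounds named here, the only evidence is that all three compounds sit at the same limit, which gives no reason to expect compound 4 to depart from it.

Compound 4 is therefore expected to give 200000 nM, with a range from 100000 nM to 400000 nM. The step of a number no higher from compound 3 to compound 4 (the limit leaves the size open) is estimated to stay within the scatter, and the assay is expected most likely to report a limit again.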

Compound 4, half-maximal inhibitory concentration: > 200000 nM
Compound 4: a limit, no number; the forecaster's own chance of this, stated with the estimate: 80%; the middle value lies on the limit itself.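

In this assay compound 4 gives > 200000 nM, a limit and not a number. Its steps from compound 1, compound 2 and compound 3 cannot be read in size or direction: the limit of > 200000 nM in this assay, at which 4 of the 4 values shown sit.

The compounds shown leave open how far these four actually differ in this assay, and whether any amide group on the shared core would give a number there.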